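Swapping the Amide Ring: Furan to Pyridine

The source may report more compounds than this note shows. Statements on the series, on what has been measured and on what is new or still open speak of the compounds shown alone.

Compound 1 `O=C(Nc1nc(-c2ccccc2)nc2cn(-c3ccccc3)nc12)c1ccco1`: 24 nM
Compound 2 `Cc1nc(NC(=O)c2ccco2)c2nn(-c3ccccc3)cc2n1`: 20 nM

In an assay on CHO cells for displacement of a labelled ligand from adenosine receptor A3 (Homo sapiens), read by scintillation counting, with a stated time of 60 min (a lower number here means a stronger inhibitor, a higher number a weaker inhibitor), compound 2 gives 20 nM, and compound 1 gives 24 nM, a pair within the scatter, so the two stand level. Going by the values given here, the only measured step, a 1.2-fold lower number from compound 1 to compound 2 (0.08 log units; within the scatter), concerns a different part of the molecule and does not bear on the change that follows. Compound 3 `Cc1nc(NC(=O)c2cccnc2)c2nn(-c3ccccc3)cc2n1` differs from compound 2 by pyridin-3-yl in place of furan-2-yl on a carbonyl carbon. With nothing measured at this position, a modest weakening is expected for compound 3, estimated at 60 nM, within 15 nM to 250 nM, that is a 3.0-fold higher number from compound 2 to compound 3 (0.48 log units; beyond the scatter).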

Compound 3, inhibition constant: 5.3 nM
Beside the measured number, compound 3's estimate is 11-fold (1.05 log units) above it; measured number below the stated range.
By their numbers in this assay, from the lowest: compound 3; then compounds 2 and 1 (each within the scatter of the next).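

Going by these compounds alone, at this position on the carbonyl carbon, the amide ring can be exchanged without any loss of strength in this assay: pyridin-3-yl in place of furan-2-yl gives a 3.8-fold lower number from compound 2 to compound 3 (0.58 log units; beyond the scatter) as the first reading here. The six-membered ring is therefore accepted at least as well as the five-membered one, and in fact modestly better. No measurement at hand explains this gain.

As far as these compounds go, whether the ring nitrogen matters stays open, and phenyl on the same carbonyl carbon would separate its role from that of ring size. Pyridin-4-yl would show whether moving that nitrogen changes the number.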